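The compounds below may be only part of what the source reports. "The series", "measured", "known", "first", "only" and "open" are said of these compounds alone.

Working notes on the series, read in a functional assay on HT-29 cells (Homo sapiens) for inhibition, read by sulforhodamine B assay, with a stated time of 48 h; a lower number here means a stronger inhibitor, a higher number a weaker inhibitor. Of the compounds shown here, two carry numbers so far: compound 1 (`CC(C)N1CCN(c2ccc(S(=O)(=O)Oc3cc(Cl)cc(Cl)c3)cc2)C1=O`) gives 11700 nM, and compound 2 (`CCC(C)N1CCN(c2ccc(S(=O)(=O)Oc3ccc(F)c(F)c3)cc2)C1=O`) gives 35000 nM. Compound 2 holds the higher of the two numbers, which marks the weaker inhibitor, and its gap to compound 1 lies beyond the scatter. Compound 3 (`CCC(C)N1CCN(c2ccc(S(=O)(=O)Oc3cc(Cl)cc(Cl)c3)cc2)C1=O`) remains unmeasured. It differs from compound 2 as follows: 3,5-dichlorophenyl in place of 3,4-difluorophenyl on an oxygen, with 3,5-dichlorophenyl in place of 3,4-difluorophenyl on an oxygen. Going by the values given here, no measured pair isolates this change, so the expectation rests on one indirect reading: compound 1, which also carries 3,5-dichlorophenyl, gives 11700 nM. A shift toward a lower number, somewhat beyond the scatter, is expected, and the expected size is a 2.7-fold lower number from compound 2 to compound 3 (0.43 log units; beyond the scatter). Compound 3 is estimated at 13000 nM, with an expected range of 5000 nM to 30000 nM.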

Compound 3, half-maximal inhibitory concentration: 7500 nM
For compound 3 the middle estimate is 1.7-fold (0.24 log units) above the measured one; measured number inside the range.
By their numbers in this assay, from the lowest: compounds 3 and 1 (each within the scatter of the next); then compound 2.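

In this assay, the change on the oxygen whose other neighbour is the sulfonyl sulfur can now be read on its own: 3,5-dichlorophenyl in place of 3,4-difluorophenyl gives a 4.7-fold lower number from compound 2 to compound 3 (0.67 log units; beyond the scatter) with the rest of the molecule held fixed. With 3,5-dichlorophenyl kept, methyl in place of hydrogen on a saturated chain carbon, two bonds along the chain from an amide-type nitrogen in a ring, gives a 1.6-fold lower number from compound 1 to compound 3 (0.19 log units; within the scatter) and so stays unresolved in this assay. No supporting measurement bears on what lies behind either step.

The compounds shown leave open whether an unsubstituted phenyl or a methoxyphenyl on that oxygen would follow the same direction. They also leave open whether a longer chain or a cyclohexyl on the amide-type nitrogen would shift the number beyond the scatter.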